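A Fluorinated Phenyl Replaces a Benzyl on the Amide

A few compounds are considered here, and "the series" means these few. Any claim that something is new, unique, unknown or untested is made for them only; others in the source may bear on it.

Within the data shown here, in an ADME assay on BaF3 cells (Mus musculus) for antiproliferative activity, read by CCK-8 assay, with a stated time of 72 h (a higher number here means a weaker inhibitor of growth, a lower number a stronger inhibitor of growth), compound 3 `O=C(CCSc1ccc2c(/C=C/c3ccccn3)n[nH]c2c1)NCc1cccc(C(F)(F)F)c1` gives 8030 nM, the only true number so far. Compound 1 `CNC(=O)CCSc1ccc2c(/C=C/c3ccccn3)n[nH]c2c1` reports only a limit, > 10000 nM. Compound 2 `Cc1cccc(NC(=O)CCSc2ccc3c(/C=C/c4ccccn4)n[nH]c3c2)c1` also reports only a limit, > 10000 nM.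

Compound 4 `O=C(CCSc1ccc2c(/C=C/c3ccccn3)n[nH]c2c1)Nc1ccc(F)c(C(F)(F)F)c1` differs from compound 3 as follows: 4-fluoro-3-(trifluoromethyl)phenyl in place of 3-(trifluoromethyl)benzyl on an amide-type nitrogen. The nearest guide is an at least 1.2-fold lower number from compound 2 to compound 3 (0.09 log units; that floor lies within the scatter), which also swaps the aromatic group on the amide-type nitrogen, though its floor lies within the scatter. Similarly, an at least 1.2-fold lower number from compound 1 to compound 3 (0.09 log units; that floor lies within the scatter) has a floor within the scatter, and a step that the two limits leave unreadable from compound 1 to compound 2 cannot be sized. These steps give no firm basis for a real shift, so the expected change, a 1.0-fold lower number from compound 3 to compound 4 (0.00 log units; within the scatter), is estimated to stay within the scatter. Compound 4 is expected at 8000 nM, with an estimated range of 3000 nM to 15000 nM.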

Compound 4, concentration for 50% growth inhibition: 610 nM
Beside the measured number, compound 4's estimate is 13-fold (1.12 log units) above it; measured number below the stated range.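

In this assay, among these compounds, the group on the amide-type nitrogen moves the number by a margin beyond the scatter for the first time: 4-fluoro-3-(trifluoromethyl)phenyl in place of 3-(trifluoromethyl)benzyl gives a 13-fold lower number from compound 3 to compound 4 (1.12 log units; beyond the scatter). The same group gives an at least 16-fold lower number from compound 2 to compound 4 (1.21 log units; beyond the scatter) and an at least 16-fold lower number from compound 1 to compound 4 (1.21 log units; beyond the scatter). Both of these sizes are floors set by an assay limit: the limit of > 10000 nM in this assay, at which 2 of the 4 values shown sit.

Going by these compounds, compound 4 adds a fluorine and drops the benzyl chain carbon in one step, so which change matters stays open. A plain 3-(trifluoromethyl)phenyl would separate the two, and whether an amine or carboxylic acid on that ring keeps the gain is also unknown.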